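Benzyloxy in place of nitro on the shared core

The source may hold more compounds than are shown below. What is called first, only, known or untested is meant among the compounds shown, and "the series" means these compounds.

Among the measured compounds shown here, in a functional assay on HT-1080 cells (Homo sapiens) for antiproliferative activity, read by MTT assay, with a stated time of 72 h (on this read-out higher numbers stand for weaker inhibition and lower numbers for stronger inhibition), compound 3 `COc1ccc(-c2sccc2-c2cc(OC)c(OC)c(OC)c2)cc1[N+](=O)[O-]` gives 2100 nM, the only true number so far. Compound 4 `COc1ccc(-c2sccc2-c2cc(OC)c(OC)c(OC)c2)cc1OCc1ccccc1` differs from it by benzyloxy in place of nitro on an aromatic carbon, ortho to a methoxy group.

Benzyloxy also occurs, with an ethyl ester on the core that compound 4 lacks, in compound 1 `CCOC(=O)c1cc(-c2cc(OC)c(OC)c(OC)c2)c(-c2ccc(OC)c(OCc3ccccc3)c2)s1`, which gives > 100000 nM, a limit. Compound 2 `COc1ccc(-c2sc(C(=O)O)cc2-c2cc(OC)c(OC)c(OC)c2)cc1OCc1ccccc1`, with a carboxylic acid in place of that ester, gives > 100000 nM, also a limit. For the measured compounds named here, the one measured step, a step that the two limits leave unreadable from compound 1 to compound 2, has no readable size and offers no scale for the change at hand.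

The expected direction rests on compound 1 and compound 2, which together make up (the limit of > 100000 nM in this assay, at which 2 of the 3 values shown sit). Weaker inhibition is therefore expected in this assay, with the size poorly defined. The expected step is a 7.1-fold higher number from compound 3 to compound 4 (0.85 log units; beyond the scatter). For compound 4 the estimate is 15000 nM, with an expected range of 3000 nM to 80000 nM.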

Compound 4, half-maximal inhibitory concentration: > 100000 nM
Compound 4 ended at the assay's limit; the forecaster's own chance of this, stated with the estimate: 30%; middle value at least 6.6-fold (0.82 log units) away from the limit.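

In this assay, benzyloxy in place of nitro on this aromatic carbon, ortho to a methoxy group, goes with an at least 47-fold higher number from compound 3 to compound 4 (1.67 log units; beyond the scatter) on the shared core. Compound 4 gives > 100000 nM, which is a limit, so this step sets only a minimum size. The steps from compound 1 and from compound 2 to compound 4 join two limits and cannot be read, but dropping the ethyl ester or the carboxylic acid does not bring the benzyloxy compounds to a true number: the limit of > 100000 nM in this assay, at which 3 of the 4 values shown sit.

On these data alone, whether any group other than nitro keeps a true number at this position stays open; an amine, a hydroxy group or an ethoxy group there would test this. Also open, as far as these compounds go, is what an ethyl ester or a carboxylic acid on the core does when nitro is kept.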